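This account rests on a few compounds, and the source may have more. Where it says the series, first, only, none or still open, it means among the compounds named here.

Compounds measured so far in an assay on isolated protein for inhibition of eIF-2-alpha kinase GCN2 (Homo sapiens); on this read-out higher numbers stand for weaker inhibition and lower numbers for stronger inhibition: compound 1 `COCCC(=O)N[C@@H]1CC[C@@H](Nc2ncc3c(Br)nn(-c4ccc5ncccc5c4)c3n2)C1` gives 74 nM; compound 2 `Brc1nn(-c2ccc3ncccc3c2)c2nc(N[C@@H]3CC[C@@H](c4ncc[nH]4)C3)ncc12` gives 21 nM; compound 3 `CS(=O)(=O)N1CC[C@@H](Nc2ncc3c(Br)nn(-c4ccc5ncccc5c4)c3n2)C1` gives 90 nM.

Compound 3 has the highest number of the three, though its gap to compound 1 lies within the scatter, and only its gap to compound 2 is beyond it, seen as a 4.3-fold higher number from compound 2 to compound 3 (0.63 log units; beyond the scatter). Compound 4 `CNC(=O)[C@@H]1CC[C@@H](Nc2ncc3c(Br)nn(-c4ccc5ncccc5c4)c3n2)C1` differs from compound 3 in one place: a group of 9 heavy atoms (7 carbon, 1 nitrogen, 1 oxygen; one five-membered non-aromatic ring of carbon only) in place of a group of 9 heavy atoms (5 carbon, 1 nitrogen, 2 oxygen, 1 sulfur; one five-membered non-aromatic ring with 1 hetero atom), on a nitrogen on an aromatic ring. The change returns to a saturated carbon ring of the kind carried by compounds 1 and 2, now bearing an amide with one hydrogen-bond donor. The two measured steps bear on this: a 4.3-fold higher number from compound 2 to compound 3 (0.63 log units; beyond the scatter) shows what moving away from such a carbon ring did, and a 3.5-fold lower number from compound 1 to compound 2 (0.55 log units; beyond the scatter) shows the spread between two substituents on that same ring. Since the amide of compound 4 resembles the amide of compound 1 more than the imidazolyl of compound 2, compound 4 is expected to land close to compound 1, a small step downward from compound 3, a 1.5-fold lower number from compound 3 to compound 4 (0.18 log units; within the scatter), likely within the scatter. The estimate for compound 4 is 60 nM, ranging from 25 nM to 150 nM.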

Compound 4, half-maximal inhibitory concentration: 21 nM
Compound 4: middle estimate off by 2.9-fold (0.46 log units), on the high side, outside the stated range (below it).
By their numbers in this assay, from the lowest: compounds 2 and 4 (each within the scatter of the next); then compounds 1 and 3 (each within the scatter of the next).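

In this assay, methylcarbamoyl on the saturated carbon ring gives a 4.3-fold lower number from compound 3 to compound 4 (0.63 log units; beyond the scatter) as the 1-(methylsulfonyl)pyrrolidin-3-yl group leaves the nitrogen position, so this carbon ring can carry a low number with an amide on it. For the compounds shown here, the amide itself does not fix the number: methylcarbamoyl in place of ((2-methoxyethyl)carbonyl)amino gives a 3.5-fold lower number from compound 1 to compound 4 (0.55 log units; beyond the scatter) on the same ring carbon, while methylcarbamoyl in place of 1H-imidazol-2-yl gives no change at the digits printed from compound 2 to compound 4 (within the scatter) and so shows that the imidazole is not the only group on this ring to reach such a number. No supporting evidence accounts for these differences. Still open, from the compounds shown here alone, is how a primary amine or a carboxylic acid would read at this ring carbon. So is the effect of a longer chain on the amide nitrogen, such as ethyl in place of methyl.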